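A Flipped Ring Stereocentre and the Amine Proton

A few compounds are considered here, and "the series" means these few. Any claim that something is new, unique, unknown or untested is made for them only; others in the source may bear on it.

Two esters built on the same bicyclic amine core have been measured for how readily they give up a proton. Compound 1 `COc1cc(C(=O)O[C@@H]2CCC[C@@H]3CCN(C)C[C@@H]32)cc(OC)c1OC` carries a trimethoxy-substituted benzoate, and in a physicochemical assay for acid dissociation, compound 1 gives 8.91. Compound 2 `CN1CC[C@H]2CCC[C@@H](OC(=O)c3ccc(Cl)cc3)[C@H]2C1` carries a chlorobenzoate instead, and in this assay compound 2 gives 8.9. The two numbers lie within the usual scatter of each other, so compound 1 cannot be set apart from compound 2 on this read-out.

Compound 3 `COc1cc(C(=O)O[C@@H]2CCC[C@@H]3CCN(C)C[C@H]32)cc(OC)c1OC` has not yet been measured. Compared with compound 1, (the two compounds have the same atoms and bonds and differ only in configuration as drawn: 1 of 3 stereo elements differ; a stereocentre at a saturated ring carbon is drawn R in compound 1 and S in compound 3). Since swapping one aromatic group for another left the value essentially unchanged, a change in drawn configuration alone is expected to produce no step beyond the scatter. For compound 3 the value in this assay is estimated at 8.9, within a range from 8.5 to 9.3. The expected step of a number 0.01 log units lower from compound 1 to compound 3 (within the scatter) is therefore estimated to be negligible.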

Compound 3, acid dissociation constant: 8.82
The estimate for compound 3 lay 0.08 log units above the measured number; low and high end bracket the measured number.
By their numbers in this assay, from the lowest: compounds 3, 2 and 1 (each within the scatter of the next).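

Within the data shown here, this is the first step between compounds that differ in one place, and it isolates a single saturated ring carbon, drawn R in compound 1 and S in compound 3. In this assay, this inversion gives a number 0.09 log units lower from compound 1 to compound 3 (within the scatter), so at this position the read-out does not separate the two drawn configurations. The comparison is a clean one, as any effect of the inversion has a single possible source: the fact that compounds 1 and 3 differ only in the configuration as drawn

Going by these compounds, the other two stereo elements remain untested, so this result cannot be extended to them or to inverting more than one at a time. On these data alone, it also remains open how this assay would respond if a larger structural change were made at this same position, such as an amide in place of the ester.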